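A few compounds are considered here, and "the series" means these few. Any claim that something is new, unique, unknown or untested is made for them only; others in the source may bear on it.

Compound 2 `Cc1ccc(NC(=O)Nc2nc(-c3cc4ccccc4o3)cs2)cc1` gives the lowest number among the three compounds measured in a physicochemical assay, with a stated time of 6 min (a lower number here means a stronger inhibitor, a higher number a weaker inhibitor), at 500 nM. Compound 1 `O=C(Nc1nc(-c2cc3ccccc3o2)cs1)Nc1ccccc1F` stands nearest to it, at 2630 nM; compound 3 `COc1ccc(NC(=O)Nc2nc(-c3cc4cc([N+](=O)[O-])ccc4o3)cs2)cc1` lies furthest away, at 121000 nM. Among the compounds with values here, the one step that joins two measured compounds differing in a single place is a 5.3-fold lower number from compound 1 to compound 2 (0.72 log units; beyond the scatter).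

Compound 4 `COc1ccc(NC(=O)Nc2nc(-c3cc4ccccc4o3)cs2)cc1` is reached from compound 2 by methoxy in place of methyl on an aromatic carbon. Within the data shown here, no measured step changes a methyl into a methoxy, so the expectation rests on indirect evidence. The step from compound 1 to compound 2 shows that a change on this ring can move this assay by a modest amount, but it swaps a different group at a different ring position. Compound 3 carries the same methoxy group as compound 4, yet it differs from compound 4 elsewhere as well, so its value cannot be read as a guide. On that basis the step from compound 2 to compound 4 is expected to stay within the scatter, a 1.4-fold higher number from compound 2 to compound 4 (0.15 log units; within the scatter), and compound 4 is estimated at 700 nM, in a range from 250 nM to 2000 nM.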

Compound 4, half-maximal inhibitory concentration: 17400 nM
For compound 4 the middle estimate is 25-fold (1.40 log units) below the measured one; measured number outside the range, above it.
By their numbers in this assay, from the lowest: compound 2; then compound 1; then compound 4; then compound 3.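

In this assay, within the data shown here, this position on the ring proves far less tolerant than the earlier compounds could show: a single added oxygen separates two very different results, with a 35-fold higher number from compound 2 to compound 4 (1.54 log units; beyond the scatter). The 4-methoxyphenyl group also compares poorly with the 2-fluorophenyl group, giving a 6.6-fold higher number from compound 1 to compound 4 (0.82 log units; beyond the scatter), while the step that keeps the methoxy and removes the nitro gives a 7.0-fold lower number from compound 3 to compound 4 (0.84 log units; beyond the scatter), so the methoxy accounts for only part of the high number of compound 3. No measurement available here offers an explanation for the size of the methyl-to-methoxy step.

The compounds shown leave open whether other groups at this position, such as a hydroxyl, an ethyl or a chlorine atom, behave like the methyl or the methoxy. They also leave open whether the nitro group would have the same effect alongside the 4-methylphenyl group.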